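Para-Substituent Changes on a Piperidinyl-Pyrimidine Sulfamide Series

A few compounds are considered here, and "the series" means these few. Any claim that something is new, unique, unknown or untested is made for them only; others in the source may bear on it.

Measured compounds:
compound 1, `Cc1ccc(-c2cc(N3CCC(CCNS(N)(=O)=O)CC3)ncn2)cc1`, gives 47500 nM in a functional assay on MCF7 cells (Homo sapiens) for antiproliferative activity, read by sulforhodamine B assay, with a stated time of 48 h; on this read-out lower numbers stand for stronger inhibition of growth and higher numbers for weaker inhibition of growth
compound 2, `COc1ccc(-c2cc(N3CCC(CCNS(N)(=O)=O)CC3)ncn2)cc1`, gives 56600 nM in this assay
compound 3, `NS(=O)(=O)NCCC1CCN(c2cc(-c3ccc(Cl)cc3)ncn2)CC1`, gives 19700 nM in this assay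

Compound 3 holds the lowest number of the three in this assay. Its nearest neighbour is compound 1, with the step of a 2.4-fold lower number from compound 1 to compound 3 (0.38 log units; beyond the scatter); further away lies compound 2, with the step of a 2.9-fold lower number from compound 2 to compound 3 (0.46 log units; beyond the scatter). Compounds 1 and 2 sit within the scatter of each other, a 1.2-fold higher number from compound 1 to compound 2 (0.08 log units; within the scatter).

Compound 4, `COC(=O)c1ccc(-c2cc(N3CCC(CCNS(N)(=O)=O)CC3)ncn2)cc1`, carries the change (methoxycarbonyl in place of chloro on an aromatic carbon). Within the data shown here, no measured step exchanges chloro for a carbonyl-bearing group, so the three steps bear on it only indirectly: they show that swapping one small group for another on this aromatic carbon moves the number in this assay by a modest amount at most. On that basis compound 4 is expected to land back among the weaker members, with an estimated step of a 2.5-fold higher number from compound 3 to compound 4 (0.40 log units; beyond the scatter). The estimate for compound 4 in this assay is 50000 nM, with a range from 15000 nM to 150000 nM.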

Compound 4, concentration for 50% growth inhibition: 17600 nM
The estimate for compound 4 lay 2.8-fold (0.45 log units) above the measured number; low and high end bracket the measured number.
By their numbers in this assay, from the lowest: compounds 4 and 3 (each within the scatter of the next); then compounds 1 and 2 (each within the scatter of the next).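

In this assay, methoxycarbonyl on this aromatic carbon, para to a large group, stands level with chloro (a 1.1-fold lower number from compound 3 to compound 4 (0.05 log units; within the scatter)), so four heavy atoms with two hydrogen-bond acceptors replace a single chlorine with no step beyond the scatter. Methoxycarbonyl also separates from methoxy (a 3.2-fold lower number from compound 2 to compound 4 (0.51 log units; beyond the scatter)) and from methyl (a 2.7-fold lower number from compound 1 to compound 4 (0.43 log units; beyond the scatter)), which divides these four compounds into two pairs: chloro with methoxycarbonyl, and methyl with methoxy. Nothing available explains this division.

Going by these compounds, whether the division holds for other groups on this carbon, such as a carboxylic acid, an amine or a nitrile, stays open. Also open, on these data alone, is whether an amide in place of methoxycarbonyl would fall with compound 3 and compound 4 or with compound 1 and compound 2.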